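The compounds below may be only part of what the source reports. "The series", "measured", "known", "first", "only" and "open" are said of these compounds alone.

The compounds in this set share a core built around a substituted indole bearing a basic piperidine, and they differ in the group carried on an amine nitrogen that sits on a saturated ring carbon of that piperidine. Compound 1 `CC(=O)Nc1ccc([C@H](C)NCC2CCN(CCCc3c[nH]c4ccc(-n5cnnc5)cc34)CC2)cc1` gives 3 nM in an assay on CHO cells for agonist activity at 5-hydroxytryptamine receptor 1D (Homo sapiens), read by GTPgammaS binding; on this read-out lower numbers stand for an effect already at smaller amounts and higher numbers for an effect only at larger amounts of compound. Compound 2 `c1cc(CNC2CCN(CCCc3c[nH]c4ccc(-n5cnnc5)cc34)CC2)co1` gives 7.1 nM in this assay, and compound 3 `C[C@@H](NC1CCN(CCCc2c[nH]c3ccc(-n4ccnc4)cc23)CC1)c1ccccc1` gives 6.2 nM. Among these three numbers compound 2 stands highest; its gap to compound 3 lies within the usual scatter of repeated measurements, while its gap to compound 1 lies beyond it.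

Compound 4 `C[C@H](NC1CCN(CCCc2c[nH]c3ccc(-n4cnnc4)cc23)CC1)c1ccccc1` has not yet been measured. It differs from compound 2 in one place: 1-phenylethyl in place of (furan-3-yl)methyl on an amine nitrogen. Compound 3 already carries a 1-phenylethyl group on the same nitrogen, though with a different ring on the core, and compound 1 carries a substituted 1-phenylethyl group with the same core ring as compound 4. Both of those compounds give numbers at or below that of compound 2, so the step from compound 2 to compound 4 is expected to be small and directed toward lower numbers, a 1.8-fold lower number from compound 2 to compound 4 (0.25 log units; within the scatter), probably not far beyond the scatter. Compound 4 is therefore estimated at 4 nM, with a range from 1.5 nM to 12 nM.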

Compound 4, half-maximal effective concentration: 12 nM
Compound 4: middle estimate off by 3.0-fold (0.48 log units), on the low side, within the range that was stated.
By their numbers in this assay, from the lowest: compound 1; then compounds 3, 2 and 4 (each within the scatter of the next).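

In this assay, for the compounds shown here, replacing (furan-3-yl)methyl with 1-phenylethyl on the amine nitrogen gives a 1.7-fold higher number from compound 2 to compound 4 (0.23 log units; within the scatter), the first comparison in this set in which only this group differs. This position therefore accepts a change from a five-membered aromatic ring with one hetero atom to a six-membered aromatic ring of carbon only, with the loss of the furan's hydrogen-bond acceptor and the gain of a defined stereocentre, and the read-out cannot tell the two compounds apart. No separate measurement speaks to how either group acts at this position.

Still open, on these data alone, is whether this tolerance extends to a plain benzyl group, which lacks the methyl of 1-phenylethyl, or to a phenyl ring carrying a carboxylic acid or an amine, groups that would test the position more sharply than this one exchange can. Going by these compounds alone, the mirror-image form of 1-phenylethyl on this same core is also open, so the single step says nothing yet about whether the stereocentre matters here.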